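From 3-Amino-4-methoxybenzyl to 4-Bromobenzyl

This account rests on a few compounds, and the source may have more. Where it says the series, first, only, none or still open, it means among the compounds named here.

In a functional assay on MGC-803 cells (Homo sapiens) for antiproliferative activity, read by MTT assay, with a stated time of 48 h (a lower number here means a stronger inhibitor, a higher number a weaker inhibitor), three compounds sharing one core have been measured: compound 1 `COc1ccc(CN(C(=O)CSc2nc3ccccc3s2)c2cc(OC)c(OC)c(OC)c2)cc1` gives 163 nM, compound 2 `COc1ccc(CN(C(=O)CSc2nc3ccccc3s2)c2cc(OC)c(OC)c(OC)c2)cc1C(F)(F)F` gives 25200 nM, and compound 3 `COc1ccc(CN(C(=O)CSc2nc3ccccc3s2)c2cc(OC)c(OC)c(OC)c2)cc1N` gives 84 nM. Compound 3 shares the low end of this range with its nearest neighbour, as the data show a 1.9-fold lower number from compound 1 to compound 3 (0.29 log units; within the scatter) and a 300-fold lower number from compound 2 to compound 3 (2.48 log units; beyond the scatter).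

Compound 4 `COc1cc(N(Cc2ccc(Br)cc2)C(=O)CSc2nc3ccccc3s2)cc(OC)c1OC` differs from compound 3 at one place, on a saturated chain carbon bound to an amide-type nitrogen, where 4-bromophenyl stands in place of 3-amino-4-methoxyphenyl (4-bromophenyl in place of 3-amino-4-methoxyphenyl on a saturated chain carbon bound to an amide-type nitrogen).

For the measured compounds named here, two measured steps bear on this change. Amino in place of hydrogen on an aromatic carbon gave a 1.9-fold lower number from compound 1 to compound 3 (0.29 log units; within the scatter), so losing the amino group of compound 3 is not expected to matter much by itself. Trifluoromethyl in place of hydrogen on an aromatic carbon gave a 150-fold higher number from compound 1 to compound 2 (2.19 log units; beyond the scatter), so a large change on this aromatic ring cannot be ruled out. Going by the values given here, no measured step replaces methoxy with bromine, and that part of the change remains untested. A moderate move towards a higher number is therefore expected in this assay. The estimated step is a 5.4-fold higher number from compound 3 to compound 4 (0.73 log units; beyond the scatter). For compound 4 the expected value is 450 nM, with an estimated range from 100 nM to 3000 nM.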

Compound 4, half-maximal inhibitory concentration: 48100 nM
Estimate against measurement, compound 4: 110-fold (2.03 log units) below; the whole stated range lies below it.
By their numbers in this assay, from the lowest: compounds 3 and 1 (each within the scatter of the next); then compounds 2 and 4 (each within the scatter of the next).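

In this assay the untested part of the change proves decisive: bromo in place of methoxy on an aromatic carbon gives a 300-fold higher number from compound 1 to compound 4 (2.47 log units; beyond the scatter) on its own, against a 570-fold higher number from compound 3 to compound 4 (2.76 log units; beyond the scatter) for the full change, so the methoxy position carries nearly the whole loss, and the amino group, whose own step lay within the scatter, need not be invoked. The comparison with the trifluoromethyl compound adds a second point, with a 1.9-fold higher number from compound 2 to compound 4 (0.28 log units; within the scatter) showing that two different edits to this benzyl ring, adding trifluoromethyl while keeping methoxy and exchanging methoxy for bromo, end at the same level, well above the numbers of compounds 1 and 3. No measurement in hand explains why either edit costs so much.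

The compounds shown leave open whether the loss is specific to bromine or follows any replacement of methoxy, which a 4-chlorobenzyl, 4-methylbenzyl or 4-hydroxybenzyl group would test. They also leave open whether an amino group can recover any of the loss when bromine is present, as in a 3-amino-4-bromobenzyl group, or whether an ethoxy group is accepted in place of methoxy.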